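The source may hold more compounds than are shown below. What is called first, only, known or untested is meant among the compounds shown, and "the series" means these compounds.

In a functional assay on HCT-116 cells (Homo sapiens) for antiproliferative activity, read by MTT assay, with a stated time of 72 h (on this read-out lower numbers stand for stronger inhibition and higher numbers for weaker inhibition), compound 1 (`COc1ccc(-c2cccc(NC(=O)CCc3cccc4c3B(O)OC4)c2)cc1`) gives 160 nM and compound 2 (`O=C(CCc1cccc2c1B(O)OC2)Nc1cccc(-c2cccc(OC(F)(F)F)c2)c1`) gives 310 nM with the same core in both. These two values lie within the scatter of each other, so the numbers available do not separate compound 2 from compound 1. Compound 3 (`O=C(CCc1cccc2c1B(O)OC2)Nc1cccc(-c2cccc(C(F)(F)F)c2)c1`) has not yet been measured. It differs from compound 2 in one place, with trifluoromethyl in place of trifluoromethoxy on an aromatic carbon. Among the measured compounds shown here, no measured pair in this small set shows this exchange, so the data give no direct guide to its effect. The expectation in this assay is therefore of no step beyond the scatter, in either direction, starting from the 310 nM of compound 2. The expected change (a 1.1-fold lower number from compound 2 to compound 3 (0.04 log units; within the scatter)) is small and is an estimate only. Compound 3 is expected to give about 280 nM with an estimated range from 130 nM to 620 nM in this measurement.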

Compound 3, half-maximal inhibitory concentration: 580 nM
The estimate for compound 3 lay 2.1-fold (0.32 log units) below the measured number; measured number inside the range.
By their numbers in this assay, from the lowest: compounds 1, 2 and 3 (each within the scatter of the next, the first and the last beyond it).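

In this assay the exchange of trifluoromethoxy for trifluoromethyl, on an aromatic carbon meta to a large group, gives a 1.9-fold higher number from compound 2 to compound 3 (0.27 log units; within the scatter) and so stays unresolved from the usual variation between repeated measurements. The broader exchange of 4-methoxyphenyl for 3-(trifluoromethyl)phenyl gives a 3.6-fold higher number from compound 1 to compound 3 (0.56 log units; beyond the scatter) as a modest step, the first in this small set to stand clear of the scatter. The aryl group carried by the shared core can therefore shift the number, whereas the exchange between the two fluorinated groups cannot be told apart from the scatter. Nothing available on these compounds accounts for either step.

The compounds shown leave open whether the larger step comes from the group itself or from its place on the ring, since the two names differ in both. They also leave open whether an amine, a carboxylic acid or a simple methyl group on this same aromatic carbon would give a step beyond the scatter from trifluoromethyl, in either direction.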